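Moving From One Methyl To Two On The Sulfonamide Aryl

The compounds below may be only part of what the source reports. "The series", "measured", "known", "first", "only" and "open" are said of these compounds alone.

Three compounds share a core in which a sulfonamide links an aryl group to a second ring carrying a cyclic urea. Compound 1 `Cc1cccc(NS(=O)(=O)c2ccc(N3CCNC3=O)cc2)c1` carries a 3-methylphenyl on the sulfonamide nitrogen and in a functional assay on MCF7 cells (Homo sapiens) for antiproliferative activity, read by sulforhodamine B assay, with a stated time of 48 h (on this read-out higher numbers stand for weaker inhibition and lower numbers for stronger inhibition), compound 1 gives 190 nM. Compound 2 `Cc1ccc(NS(=O)(=O)c2ccc(N3CCNC3=O)cc2)cc1` carries a 4-methylphenyl instead, and in this assay compound 2 gives 610 nM, the highest of the three numbers shown. Compound 3 `O=C1NCCN1c1ccc(S(=O)(=O)Nc2ccc(I)cc2)cc1` carries a 4-iodophenyl, and in this assay compound 3 gives 600 nM.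

The step from compound 1 to compound 2 was a 3.2-fold higher number from compound 1 to compound 2 (0.51 log units; beyond the scatter), while the step from compound 2 to compound 3 was a 1.0-fold lower number from compound 2 to compound 3 (0.01 log units; within the scatter). Compound 4 `Cc1cc(C)cc(NS(=O)(=O)c2ccc(N3CCNC3=O)cc2)c1` has not yet been measured; relative to compound 2 the change is 3,5-dimethylphenyl in place of 4-methylphenyl on a sulfonamide nitrogen.

For the measured compounds named here, the one measured step that bears on this change is the one from compound 1 to compound 2, because a 3.2-fold higher number from compound 1 to compound 2 (0.51 log units; beyond the scatter) shows that placing the methyl as in 3-methylphenyl rather than 4-methylphenyl went with a lower number. With two methyls arranged as in 3,5-dimethylphenyl, a step of similar size in the lowering direction is expected for compound 4, namely a 2.4-fold lower number from compound 2 to compound 4 (0.39 log units; beyond the scatter), though one compound pair is thin evidence. For compound 4 the expected value in this assay is therefore 250 nM, with a range from 90 nM to 700 nM.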

Compound 4, half-maximal inhibitory concentration: 100 nM
Compound 4: the middle estimate sits 2.5-fold (0.40 log units) above what was measured; low and high end bracket the measured number.
By their numbers in this assay, from the lowest: compounds 4 and 1 (each within the scatter of the next); then compounds 3 and 2 (each within the scatter of the next).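

Swapping the 4-methylphenyl on the sulfonamide nitrogen for 3,5-dimethylphenyl gives a 6.1-fold lower number from compound 2 to compound 4 (0.79 log units; beyond the scatter) in this assay, and swapping the 4-iodophenyl for the same group gives a 6.0-fold lower number from compound 3 to compound 4 (0.78 log units; beyond the scatter), so the 3,5-dimethylphenyl group clearly outperforms both of these aryl groups on this read-out. The new information comes from the third comparison: adding a second methyl to the 3-methylphenyl group gives a 1.9-fold lower number from compound 1 to compound 4 (0.28 log units; within the scatter), so compound 1 and compound 4 cannot be told apart and the second methyl brings no measurable gain. Across these four compounds, the two with a methyl named at position 3 of the ring both give lower numbers than the two with a group at position 4, and none of the four goes against this pattern.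

Nothing shown explains why these aryl groups differ in this way. On these data alone, it remains open whether an amine, a carboxylic acid or a longer chain such as ethyl in place of the methyl on 3-methylphenyl would keep the number as low as in compound 1 and compound 4.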